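Chloro to phenyl on the 2-phenylethynyl series

A few compounds are considered here, and "the series" means these few. Any claim that something is new, unique, unknown or untested is made for them only; others in the source may bear on it.

Measured so far, in a functional assay on K562 cells (Homo sapiens) for inhibition, read by thymidine incorporation, with a stated time of 48 h; a higher number here means a weaker inhibitor, a lower number a stronger inhibitor:
- compound 1 `C(#Cc1ncnc2c1ncn2Cc1ccccc1)c1ccccc1`: 1.3 ug/mL
- compound 2 `Clc1nc(C#Cc2ccccc2)c2ncn(Cc3ccccc3)c2n1`: 0.12 ug/mL

Compound 2 holds the lowest number of the two measured compounds, and so is the stronger inhibitor in this assay. The next compound to be tested is compound 3 `C(#Cc1nc(-c2ccccc2)nc2c1ncn2Cc1ccccc1)c1ccccc1`, which has phenyl in place of chloro on an aromatic carbon, between two ring nitrogen atoms: phenyl in place of chloro on an aromatic carbon.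

Among the measured compounds shown here, one measured step bears on this change: an 11-fold lower number from compound 1 to compound 2 (1.03 log units; beyond the scatter), with chloro in place of hydrogen on that same carbon. This large step shows that the number responds strongly to what this carbon carries. It says nothing direct about phenyl, for which no measurement exists in this series. Part of the gain seen with chloro is expected to be lost, without a full return to the level of compound 1, so a moderate move towards a higher number is the working expectation. The expected step is a 3.3-fold higher number from compound 2 to compound 3 (0.52 log units; beyond the scatter). For compound 3 the estimated value is 0.4 ug/mL, with an expected range of 0.08 ug/mL to 2 ug/mL.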

Compound 3, half-maximal inhibitory concentration: 1.4 ug/mL
Compound 3: the middle estimate sits 3.5-fold (0.54 log units) below what was measured; the range from low to high includes it.
By their numbers in this assay, from the lowest: compound 2; then compounds 1 and 3 (each within the scatter of the next).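

In this assay, phenyl on this aromatic carbon, between two ring nitrogen atoms, removes the whole of the gain seen with chloro, with a 12-fold higher number from compound 2 to compound 3 (1.07 log units; beyond the scatter) as the step. The earlier compounds showed only that chloro outperforms hydrogen here; against hydrogen on the same carbon, phenyl makes no readable difference, with a 1.1-fold higher number from compound 1 to compound 3 (0.03 log units; within the scatter) as the step, so among the three groups shown on this carbon only chloro separates from the others, and a larger group in this place does not by itself carry the gain. Nothing at hand gives a reason for either the gain with chloro or its loss with phenyl.

Still open, from the compounds shown here alone, is where a bromo, a methoxy or an amine on this carbon would fall relative to chloro and hydrogen, which would show whether the gain is particular to chloro. Also open, going by these compounds, is whether the step from chloro to phenyl keeps its size when the 2-phenylethynyl group on the shared core gives way to another group, such as a longer alkyne chain.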